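From a Benzyl Arm to a Carbamoyl Arm: Compound 4

The compounds below may be only part of what the source reports. "The series", "measured", "known", "first", "only" and "open" are said of these compounds alone.

Compound 1 `NC(=O)c1c(NC(=O)c2ccccc2Cl)sc2c1CCN(Cc1c(Cl)cccc1Cl)C2` gives 28800 nM in a functional assay on HeLa cells (Homo sapiens) for antiproliferative activity, with a stated time of 24 h; on this read-out lower numbers stand for stronger inhibition and higher numbers for weaker inhibition.
Compound 2 `Cc1ccc(C(=O)Nc2sc3c(c2C(N)=O)CCN(Cc2c(Cl)cccc2Cl)C3)cc1` gives 47400 nM in this assay.
Compound 3 `NC(=O)c1c(NC(=O)c2ccccc2F)sc2c1CCN(Cc1c(Cl)cccc1Cl)C2` gives 33000 nM in this assay.

Compound 3 stands second highest of these three numbers, yet its gaps to the others, a 1.1-fold higher number from compound 1 to compound 3 (0.06 log units; within the scatter) and a 1.4-fold lower number from compound 2 to compound 3 (0.16 log units; within the scatter), are both within the scatter, so the three cannot be told apart. Compound 4 `NC(=O)c1c(NC(=O)c2ccccc2F)sc2c1CCN(C(=O)Nc1ccccc1Cl)C2` differs from compound 3 in one place: (2-chlorophenyl)carbamoyl in place of 2,6-dichlorobenzyl on an amine nitrogen in a ring. Among the measured compounds shown here, no measured step touches this position; a 1.6-fold higher number from compound 1 to compound 2 (0.22 log units; within the scatter) and a 1.4-fold lower number from compound 2 to compound 3 (0.16 log units; within the scatter) concern only the group on the carbonyl carbon. There is thus no direct guide for this change. Compound 4 is therefore expected near 35000 nM, with a deliberately wide range from 8000 nM to 150000 nM. The step is expected to be a 1.1-fold higher number from compound 3 to compound 4 (0.03 log units; within the scatter).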

Compound 4, half-maximal inhibitory concentration: > 50000 nM
Compound 4: only a limit was reported (the forecaster's own chance of this, stated with the estimate: 25%); middle value at least 1.4-fold (0.15 log units) away from the limit.
By their numbers in this assay, from the lowest: compounds 1, 3 and 2 (each within the scatter of the next). At a limit, above all of these: compound 4.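

Among the compounds shown here, this is the first result at the amine nitrogen in the ring, and (2-chlorophenyl)carbamoyl in place of 2,6-dichlorobenzyl brings no visible gain in this assay here. Compound 4 yields a limit and not a number: the limit of > 50000 nM in this assay, at which 1 of the 4 values shown sits. On these data alone, the step is an at least 1.5-fold higher number from compound 3 to compound 4 (0.18 log units; that floor lies within the scatter) and its floor alone does not show a real loss, so its true size stays unknown. Still open, as far as these compounds go, is whether the carbamoyl link or the change in chlorine counts for more. Also open, from the compounds shown here alone, is whether a methyl, an acetyl or a longer alkyl chain on this nitrogen would give a lower number.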